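This account rests on a few compounds, and the source may have more. Where it says the series, first, only, none or still open, it means among the compounds named here.

Compound 1 `COc1ccc(-c2nc3cc(/C=C4\SC(=O)NC4=O)ccc3[nH]2)cc1OC` is the stronger of the two compounds measured in a functional assay on HT-1080 cells (Homo sapiens) for inhibition, read by MTT assay, with a stated time of 48 h (a higher number here means a weaker inhibitor, a lower number a stronger inhibitor), where compound 1 gives 2430 nM. Among the measured compounds shown here, compound 2 `COc1cc(OC)c(-c2nc3cc(/C=C4\SC(=O)NC4=O)ccc3[nH]2)cc1OC` gives 6350 nM, and the only measured step is a 2.6-fold higher number from compound 1 to compound 2 (0.42 log units; beyond the scatter). Compound 3 `COc1cc(-c2nc3cc(/C=C4\SC(=O)NC4=O)ccc3[nH]2)ccc1OCC(C)C` differs from compound 1 by isopropyl in place of hydrogen on a saturated chain carbon bound to an oxygen on an aromatic ring, which read one bond further out is methoxy to isobutoxy. The step from compound 1 to compound 2 concerns a different change, so nothing measured bears directly on this one. Compound 3 is therefore expected to stay close to compound 1, with a 1.0-fold higher number from compound 1 to compound 3 (0.01 log units; within the scatter) within the scatter. The estimated value for compound 3 is 2500 nM, between 900 nM and 7000 nM.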

Compound 3, half-maximal inhibitory concentration: 4450 nM
For compound 3 the middle estimate is 1.8-fold (0.25 log units) below the measured one; measured number inside the range.
By their numbers in this assay, from the lowest: compounds 1, 3 and 2 (each within the scatter of the next, the first and the last beyond it).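

Isopropyl in place of hydrogen on a saturated chain carbon bound to an oxygen on an aromatic ring gives a 1.8-fold higher number from compound 1 to compound 3 (0.26 log units; within the scatter) in this assay. Among the compounds shown here, this is the first reading at this place, and it shows that going from methoxy to isobutoxy on the core of compound 1 does not move the number beyond the scatter. No available evidence explains this result.

A single step cannot show how far this place accepts larger groups. On these data alone, whether a longer chain, an amine or a carboxylic acid on this oxygen would give a similar number remains open.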